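A Sulfonyl Aryl Swap on a Shared Core

This account rests on a few compounds, and the source may have more. Where it says the series, first, only, none or still open, it means among the compounds named here.

Of the compounds shown here, three built on a shared core have so far been read in an ADME assay on microsomes from liver (Mus musculus), read by LC-MS, using NADPH, tested at 10 uM; a lower number here means that the liver removes a smaller share, a higher number that the liver removes a larger share of the compound in one pass. In this assay compound 1 (`O=C(NCc1ccc(F)cc1)c1ccc(N2CCN(S(=O)(=O)c3ccccc3C(F)(F)F)CC2)nn1`) gives 0.66. In the same assay compound 2 (`Cc1ccccc1S(=O)(=O)N1CCN(c2ccc(C(=O)NCc3cncs3)nn2)CC1`) gives 0.77, and compound 3 (`O=C(NCc1ccccc1)c1ccc(N2CCN(S(=O)(=O)c3cccc(Cl)c3Cl)CC2)nn1`) gives 0.81. Compound 1 thus stands lowest of the three: its nearest neighbour is compound 2, whose number lies beyond the scatter above it, and its furthest is compound 3, also beyond the scatter. For the measured compounds named here, no two of these measured compounds differ in only one place, so no single step between measured compounds can be drawn from them.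

Compound 4 (`Cc1cc(F)ccc1S(=O)(=O)N1CCN(c2ccc(C(=O)NCc3ccc(F)cc3)nn2)CC1`) awaits measurement in this assay. It differs from compound 1 in one place: 4-fluoro-2-methylphenyl in place of 2-(trifluoromethyl)phenyl on a sulfonyl sulfur. The measured set holds no change of this kind, so the expectation rests on compound 1 alone and on the narrow spread of the three numbers. Compound 4 is therefore estimated to give 0.7, within a range from 0.55 to 0.85. The expected step a number 0.040 higher from compound 1 to compound 4 (within the scatter) is a small upward one, not beyond the scatter.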

Compound 4, hepatic extraction ratio: 0.8
Beside the measured number, compound 4's estimate is 0.10 below it; measured number inside the range.
By their numbers in this assay, from the lowest: compound 1; then compounds 2, 4 and 3 (each within the scatter of the next).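

In this assay, for the compounds shown here, the exchange of 2-(trifluoromethyl)phenyl for 4-fluoro-2-methylphenyl on a sulfonyl sulfur gives the first single-place step in this set: a number 0.14 higher from compound 1 to compound 4 (beyond the scatter). With the rest of compound 1 held fixed, this shows that the aryl group on the sulfonyl sulfur can by itself move the share of compound that the liver removes, and that in this pair the 2-(trifluoromethyl)phenyl group goes with the lower number. Nothing available here bears on why the number moves in this direction.

The exchange alters two features at once, the trifluoromethyl giving way to a methyl and a fluorine entering the ring, so the step cannot be assigned to either one; a 4-fluoro-2-(trifluoromethyl)phenyl group on the same sulfonyl sulfur would help to separate them. As far as these compounds go, it also remains open whether a step of this size would recur with another amide substituent on the shared core, or whether a non-aromatic group such as cyclopropyl on the sulfonyl sulfur would bring the number lower than the 2-(trifluoromethyl)phenyl group does.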